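Dropping a methoxy group: a measured step and an expected one

This account rests on a few compounds, and the source may have more. Where it says the series, first, only, none or still open, it means among the compounds named here.

Measured in an assay on isolated protein for binding affinity to 5-hydroxytryptamine receptor 3A (Homo sapiens); on this read-out higher numbers stand for weaker inhibition and lower numbers for stronger inhibition:
Compound 1, `COc1cccc(-c2n[nH]cc2N2CCCNCC2)c1`: 1030 nM
Compound 2, `c1ccc(-c2n[nH]cc2N2CCCNCC2)cc1`: 2100 nM
Compound 3, `COc1ccc(-c2n[nH]cc2N2CCNCC2)cc1`: a limit of this assay, > 10000 nM

Compound 1 and compound 2 differ by hydrogen in place of methoxy on an aromatic carbon, and this assay recorded a 2.0-fold higher number from compound 1 to compound 2 (0.31 log units; beyond the scatter). For compound 3 this assay reports only a limit, namely (the limit of > 10000 nM in this assay, at which 1 of the 3 values shown sits). How the core of compound 3 differs from the core of compound 1 is not broken down here.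

Compound 4, `c1ccc(-c2n[nH]cc2N2CCNCC2)cc1`, has not been measured in this assay. It differs from compound 3 by hydrogen in place of methoxy on an aromatic carbon. For the measured compounds named here, this is the same kind of change as the one from compound 1 to compound 2, but not the same: in compound 3 the group leaves a carbon para to a large group, whereas in compound 1 it left a carbon meta to a large group.

The earlier step was modest and lay beyond the scatter, while compound 3 offers only a limit as a starting point. Compound 4 is expected to show a step that the limit leaves unreadable from compound 3 to compound 4. Compound 4 is estimated at 12000 nM in this assay, with a range from 4000 nM to 40000 nM.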

Compound 4, inhibition constant: > 10000 nM
Compound 4 was reported as a limit (the forecaster's own chance of this, stated with the estimate: 55%); the middle value lies beyond the limit too.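

Compound 3 and compound 4 are both reported in this assay only as a limit, so no step between them can be read: the limit of > 10000 nM in this assay, at which 2 of the 4 values shown sit.

The compounds shown leave open how far hydrogen in place of methoxy, para to a large group, moves the number on this core, and whether that shift resembles the one between compound 1 and compound 2.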